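The source may hold more compounds than are shown below. What is called first, only, known or untested is meant among the compounds shown, and "the series" means these compounds.

In a toxicity assay (LMTK cells) for cytotoxicity, with Mus musculus as the target, read by MTT assay, with a stated time of 72 h (a higher number here means a weaker inhibitor, a lower number a stronger inhibitor), compound 3 (`Cc1c(C)c2c(c(C)c1OC(=O)CCC(=O)NC1CC(C)(C)N([O])C1(C)C)CCC(C)(C(=O)NC1CC(C)(C)N([O])C1(C)C)O2`) gives > 300000 nM as a limit of the assay, not a number. Compound 1 (`Cc1c(C)c2c(c(C)c1OC(=O)CCC(=O)O)CCC(C)(C(=O)NCC1CC(C)(C)N([O])C1(C)C)O2`) gives > 300000 nM as a limit too. Compound 2 (`Cc1c(C)c2c(c(C)c1OC(=O)CCC(=O)O)CCC(C)(C(=O)O)O2`) also gives > 300000 nM as a limit. Together these make the limit of > 300000 nM in this assay, at which 3 of the 3 values shown sit, and leave no measured number. Compound 4 (`Cc1c(C)c2c(c(C)c1OC(=O)CCC(=O)O)CCC(C)(C(=O)NC1CC(C)(C)N([O])C1(C)C)O2`) differs from compound 3 by one oxygen atom in place of a group of 11 heavy atoms (8 carbon, 2 nitrogen, 1 oxygen; one five-membered non-aromatic ring with 1 hetero atom), on a carbonyl carbon on a carbonyl carbon, where a hydroxy enters. For the measured compounds named here, the one measured step bearing on this is a step that the two limits leave unreadable from compound 1 to compound 2 with a similar exchange on a carbonyl carbon, so it offers no size to carry over. The estimated change, in no firm direction, is a step that the limit leaves unreadable from compound 3 to compound 4 and it should not be read as a real shift. Compound 4 is expected near 350000 nM with an estimated range of 200000 nM to 800000 nM and will most likely be reported only as a limit.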

Compound 4, half-maximal inhibitory concentration: > 300000 nM
Compound 4 ended at the assay's limit (the forecaster's own chance of this, stated with the estimate: 90%); the middle value is on the limit's open side.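

For the compounds shown here, no step from compound 1, compound 2 or compound 3 to compound 4 can be read, because all four compounds sit at the same limit, not at a number: the limit of > 300000 nM in this assay, at which 4 of the 4 values shown sit. As far as these compounds go, whether these compounds differ at all in this assay stays open.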